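Adding methyl to the core of compound 2

The source may hold more compounds than are shown below. What is called first, only, known or untested is meant among the compounds shown, and "the series" means these compounds.

Measured in a functional assay on Jurkat cells (Homo sapiens) for antiproliferative activity, read by MTT assay, with a stated time of 72 h; on this read-out higher numbers stand for weaker inhibition and lower numbers for stronger inhibition:
- compound 1 `COc1cc(C(=O)c2sc3ccccc3c2-c2ccc(C)cc2)cc(OC)c1OC` gives 3300 nM
- compound 2 `COc1cc(C(=O)c2sc3ccccc3c2Nc2ccc(C)cc2)cc(OC)c1OC` gives 1700 nM

For the measured compounds named here, compound 2 lies within the scatter of compound 1 on the only two numbers available. Compound 3 `COc1cc(C(=O)c2sc3cc(C)ccc3c2Nc2ccc(C)cc2)cc(OC)c1OC` differs from compound 2 by methyl in place of hydrogen on an aromatic carbon with methyl in place of hydrogen on an aromatic carbon. Going by the values given here, the sole measured step is a 1.9-fold lower number from compound 1 to compound 2 (0.29 log units; within the scatter) and it concerns a different place, so it gives no direct size for this change. No change beyond the scatter is expected in this assay and the estimated step is a 1.4-fold lower number from compound 2 to compound 3 (0.15 log units; within the scatter) on present data. For compound 3 the estimate is 1200 nM and the expected range runs from 250 nM to 4000 nM.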

Compound 3, half-maximal inhibitory concentration: 2500 nM
The estimate for compound 3 lay 2.1-fold (0.32 log units) below the measured number; the measured number falls inside the stated range.
By their numbers in this assay, from the lowest: compounds 2, 3 and 1 (each within the scatter of the next).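

In this assay, methyl in place of hydrogen on an aromatic carbon of the six-membered aromatic ring gives a 1.5-fold higher number from compound 2 to compound 3 (0.17 log units; within the scatter), so this position takes a methyl without a shift beyond the scatter. For the compounds shown here, this is the first reading of a change on this ring, as the earlier step concerned a different place. No available evidence accounts for this result.

Going by these compounds, whether a propyl chain, an amine or a carboxylic acid at this position would stay within the scatter remains open. So does the effect of methyl on the other aromatic carbons of this ring.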